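The source may hold more compounds than are shown below. What is called first, only, known or untested is meant among the compounds shown, and "the series" means these compounds.

Within the data shown here, compound 2 `CCCCCCCCCCCCCCC(COCc1ccccc1)NC(=O)CCCC(=O)O` stands lowest of the two numbers so far in an ADME assay on cells (Splenocyte, Mus musculus, strain BALB/c) for cytotoxicity, read by MTT assay, tested at 10 ug/mL (a lower number here means a weaker effect, a higher number a stronger effect of the compound at the concentration tested), giving 6.4%; its nearest neighbour is compound 1 `CCCCCCCCCCCCCCC(N)COCc1ccccc1`, which in this assay gives 12.2%. Among the measured compounds shown here, the single measured step, a number 5.8 percentage points lower from compound 1 to compound 2 (within the scatter), lies within the scatter. Compound 3 `CCCCCCCCCCCCCCC(COCc1ccccc1)N(CC)CC` differs from compound 2 by diethylamino in place of ((3-carboxypropyl)carbonyl)amino on a saturated chain carbon bound to two saturated chain carbons. For the measured compounds named here, no measured step covers a diethylamino group entering at this place, so the only comparison is the step from compound 1 to compound 2, which put the (3-carboxypropyl)carbonyl group onto the amine nitrogen without a shift beyond the scatter. On that single precedent, the change at the nitrogen of compound 2 is expected to move this assay little, and the expected step of a number 4.6 percentage points higher from compound 2 to compound 3 (within the scatter) has no direction beyond the scatter. Compound 3 is expected to give 11% in this assay, with a range from 2% to 28%.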

Compound 3, a percentage reported as activity, at one concentration (the size of the read-out at that concentration, not a potency): 15.6%
For compound 3 the middle estimate is 4.6 percentage points below the measured one; measured number inside the range.
By their numbers in this assay, from the lowest: compounds 2, 1 and 3 (each within the scatter of the next).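

At the saturated chain carbon bound to two saturated chain carbons, this assay now compares diethylamino with two other groups: a number 3.4 percentage points higher from compound 1 to compound 3 (within the scatter) against amino, and a number 9.2 percentage points higher from compound 2 to compound 3 (within the scatter) against ((3-carboxypropyl)carbonyl)amino. The earlier pair covered only the (3-carboxypropyl)carbonyl group on the amine nitrogen; these steps extend the comparison to diethylamino, and none of the three groups separates from another beyond the scatter. No evidence on hand bears on this result.

Still open, on these data alone, is whether a hydroxyl group, a piperidine or a quaternary ammonium at this carbon would also stay within the scatter in this assay at the concentration tested. Equally open, as far as these compounds go, is whether a shorter saturated chain on the shared core would move this read-out beyond the scatter.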